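Swapping a triazole for a thiophene on the amide arm

The source may hold more compounds than are shown below. What is called first, only, known or untested is meant among the compounds shown, and "the series" means these compounds.

Going by the values given here, compound 3 `CCN(Cc1c[nH]nn1)C(=O)COc1ccc(C)cc1` gives 31100 nM in an assay on HEK293 cells for agonist activity at transient receptor potential cation channel subfamily M member 8 (Homo sapiens), read by fluorescence and calcium flux, with a stated time of 15 min (a lower number here means that less compound is needed, a higher number that more compound is needed for the effect), the highest of the three numbers so far. Compound 1 `Cc1ccc(OCC(=O)N(Cc2cccs2)C2COC2)cc1` gives 23000 nM in this assay, within the usual scatter of compound 3. Compound 2 `CCCc1ccc(OCC(=O)N(CC)Cc2cccs2)cc1` gives 1810 nM in this assay, a markedly lower number than compound 3. Compound 4 `CCN(Cc1cccs1)C(=O)COc1ccc(C)cc1` has not yet been measured. The change from compound 3 to compound 4 is thiophen-2-yl in place of 1H-1,2,3-triazol-4-yl on a saturated chain carbon bound to an amide-type nitrogen. Among the compounds with values here, no measured pair shows this change alone, so its effect in this assay is uncertain; compounds 1 and 2, which both carry the entering group, give the lower numbers. Compound 4 is therefore expected to give a lower number, with the step of a 3.9-fold lower number from compound 3 to compound 4 (0.59 log units; beyond the scatter) beyond the scatter. Compound 4 is estimated at 8000 nM, between 2500 nM and 25000 nM.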

Compound 4, half-maximal effective concentration: 8 nM
Estimate against measurement, compound 4: 1000-fold (3.00 log units) above, outside the stated range (below it).
By their numbers in this assay, from the lowest: compound 4; then compound 2; then compounds 1 and 3 (each within the scatter of the next).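

In this assay thiophen-2-yl in place of 1H-1,2,3-triazol-4-yl gives a 3900-fold lower number from compound 3 to compound 4 (3.59 log units; beyond the scatter) and offers the first view of this change alone, showing that the ring on this arm can decide the result. Ethyl in place of oxetan-3-yl on the amide-type nitrogen gives a 2900-fold lower number from compound 1 to compound 4 (3.46 log units; beyond the scatter) and hydrogen in place of ethyl on a saturated chain carbon bound to an aromatic carbon gives a 230-fold lower number from compound 2 to compound 4 (2.35 log units; beyond the scatter) so those two places count as well. As far as these compounds go, whether a furan or pyridine ring on the amide arm would hold such a low number stays open. Nothing shown here explains the size of these steps.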